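Swapping the Methoxymethyl Group of Compound 2

This account rests on a few compounds, and the source may have more. Where it says the series, first, only, none or still open, it means among the compounds named here.

For the measured compounds named here, in a functional assay on MCF7 cells (Homo sapiens) for antiproliferative activity, read by MTT assay, with a stated time of 48 h (on this read-out lower numbers stand for stronger inhibition and higher numbers for weaker inhibition), compound 1 `CC(C)=CCC[C@]1(C)/C=C/[C@@H](OC(=O)C=C(C)C)[C@](C)(O)/C=C/C(=O)/C(CF)=C\C1` gives 240 nM and compound 2 `COCOC/C1=C/C[C@](C)(CCC=C(C)C)/C=C/[C@@H](OC(=O)C=C(C)C)[C@](C)(O)/C=C/C1=O` gives 3120 nM, which is the higher of the only two numbers available. Compound 3 `CSC(=S)OC/C1=C/C[C@](C)(CCC=C(C)C)/C=C/[C@@H](OC(=O)C=C(C)C)[C@](C)(O)/C=C/C1=O` has not yet been measured. It differs from compound 2 in a single group: a group of 4 heavy atoms (2 carbon, 2 sulfur; no ring) in place of a group of 3 heavy atoms (2 carbon, 1 oxygen; no ring), on an oxygen on a saturated carbon. Going by the values given here, the change sits on an oxygen on a saturated carbon, and no measured compound carries the entering group.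

Among the compounds with values here, only one measured step bears on this change, a 13-fold higher number from compound 1 to compound 2 (1.11 log units; beyond the scatter), and it is large. That step put methoxymethoxy in place of fluoro on a saturated chain carbon bound to a double-bonded ring carbon. It shows that the number can move widely with a change in this part of the molecule, but it does not test the new group, so its direction carries over only weakly. The step expected here is smaller and towards a lower number, estimated as a 2.1-fold lower number from compound 2 to compound 3 (0.32 log units; beyond the scatter). In this assay the estimate for compound 3 is 1500 nM, with an expected range from 450 nM to 5000 nM.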

Compound 3, half-maximal inhibitory concentration: 900 nM
Beside the measured number, compound 3's estimate is 1.7-fold (0.22 log units) above it; low and high end bracket the measured number.
By their numbers in this assay, from the lowest: compound 1; then compound 3; then compound 2.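

In this assay, the oxygen on a saturated carbon stays in place in both compounds, yet the group it carries still shifts the number, with a 3.5-fold lower number from compound 2 to compound 3 (0.54 log units; beyond the scatter). The earlier step could not show this, as it replaced the whole methoxymethoxy unit with fluoro and so left open whether the group on that oxygen mattered by itself. The new group closes only part of the gap, since a 3.8-fold higher number from compound 1 to compound 3 (0.57 log units; beyond the scatter) shows that the fluoro compound keeps the lowest number of the three, and nothing at hand offers any measured account of either shift.

The compounds shown leave open whether a free hydroxyl at this place, an acetyl group on the oxygen or a longer chain such as ethoxymethyl would fall nearer to compound 3 or to compound 2, and whether any group on this oxygen can match compound 1 at 240 nM. They also leave open whether the sulfur atoms matter at all, a question that a methyl carbonate, the all-oxygen counterpart of the entering group, would help to settle.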